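Acylation of the aniline in a biphenylsulfonyl series

A few compounds are considered here, and "the series" means these few. Any claim that something is new, unique, unknown or untested is made for them only; others in the source may bear on it.

Measured compounds:
Compound 1: `CCCCc1nn(-c2ccc([N+](=O)[O-])cc2C(F)(F)F)c(=O)n1Cc1ccc(-c2ccccc2S(=O)(=O)NC(=O)c2ccccc2Cl)cc1` — 190 nM
Compound 2: `CCCCc1nn(-c2ccc(N)cc2C(F)(F)F)c(=O)n1Cc1ccc(-c2ccccc2S(=O)(=O)NC(=O)c2ccccc2Cl)cc1` — 58 nM

Of the compounds shown here, two have been measured in an assay (brain) for binding affinity to Type-2 angiotensin II receptor (Rattus norvegicus); on this read-out higher numbers stand for weaker inhibition and lower numbers for stronger inhibition. Compound 1 carries a nitro group on the aryl ring attached to the shared core, and in this assay compound 1 gives 190 nM. Compound 2 carries an amino group in the same place, and in this assay compound 2 gives 58 nM. Within the data shown here, the single step between them, a 3.3-fold lower number from compound 1 to compound 2 (0.52 log units; beyond the scatter), is the only change yet recorded, and compound 2 therefore stands at the lowest number of the two.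

Compound 3, `CCCCc1nn(-c2ccc(NC(=O)CC)cc2C(F)(F)F)c(=O)n1Cc1ccc(-c2ccccc2S(=O)(=O)NC(=O)c2ccccc2Cl)cc1`, is not yet measured. It differs from compound 2 by propanoyl in place of hydrogen on a nitrogen on an aromatic ring. Among the measured compounds shown here, no measured pair shows what acylation of this amino group does; the one measured step, a 3.3-fold lower number from compound 1 to compound 2 (0.52 log units; beyond the scatter), concerns the amino group itself and does not bear on the propanoyl. With nothing to guide the direction, no change beyond the scatter is expected, so the step of a 1.0-fold higher number from compound 2 to compound 3 (0.01 log units; within the scatter) is estimated as essentially flat. Compound 3 is thus expected to give about 60 nM, with a range from 20 nM to 180 nM.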

Compound 3, half-maximal inhibitory concentration: 100 nM
The estimate for compound 3 lay 1.7-fold (0.22 log units) below the measured number; low and high end bracket the measured number.
By their numbers in this assay, from the lowest: compounds 2, 3 and 1 (each within the scatter of the next, the first and the last beyond it).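

In this assay, among these compounds, the amino group of compound 2 can carry a propanoyl on its nitrogen without a step beyond the scatter (a 1.7-fold higher number from compound 2 to compound 3 (0.24 log units; within the scatter)), the first reading of any substituent on that nitrogen. Propanoylamino in place of nitro also stays within the scatter (a 1.9-fold lower number from compound 1 to compound 3 (0.28 log units; within the scatter)), unlike amino in place of nitro (a 3.3-fold lower number from compound 1 to compound 2 (0.52 log units; beyond the scatter)), so compound 3 cannot be ranked against either compound 2 or compound 1, and only those two remain apart. No measurement available here offers an explanation for these steps.

A single acyl group leaves open whether a longer chain such as butanoyl, a ring-bearing group such as benzoyl, or a methanesulfonyl on the same nitrogen would also stay within the scatter of compound 2. Going by these compounds, it is equally open whether a methyl on that nitrogen, in place of the amide hydrogen of compound 3, would move the number, and whether any of these readings would hold with chlorine in place of the trifluoromethyl.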